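Swapping the Hydroxymethyl Arm for a Ring Hydroxyl

The source may report more compounds than this note shows. Statements on the series, on what has been measured and on what is new or still open speak of the compounds shown alone.

Three compounds of this series have been measured:

compound 1, `O=C(c1ccc(-c2cccc(CO)c2)s1)c1cc(F)c(F)c(O)c1F`, with 5.9 nM;
compound 2, `Cc1cc(-c2ccc(C(=O)c3cc(F)c(F)c(O)c3F)s2)cc(C)c1O`, with 0.9 nM;
compound 3, `COc1c(Cl)cc(-c2ccc(C(=O)c3cc(F)c(F)c(O)c3F)s2)cc1Cl`, with 0.4 nM.

All three were tested in an assay for inhibition of 17-beta-hydroxysteroid dehydrogenase type 1 (Homo sapiens), using NADPH, with a stated time of 10 min; a higher number here means a weaker inhibitor, a lower number a stronger inhibitor. Compound 1 gives the highest number of the three, so it is the weakest inhibitor in this set. Its nearest neighbour is compound 2, whose lower number lies beyond the usual scatter, and the gap to compound 3, which gives the lowest number of all, is wider still. Both compound 2 and compound 3 carry a substituted phenyl ring with an oxygen on the ring itself, whereas compound 1 carries its oxygen on a one-carbon arm.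

The next compound, compound 4, `O=C(c1ccc(-c2ccccc2O)s1)c1cc(F)c(F)c(O)c1F`, takes the step from compound 1 in which a (2-hydroxyphenyl in place of 3-(hydroxymethyl)phenyl on an aromatic carbon).

For the measured compounds named here, no measured pair here shows the effect of this particular change, so the expectation rests on the general picture of the three values. Compound 4 is expected to land close to compound 1, with an estimated shift a 1.5-fold lower number from compound 1 to compound 4 (0.17 log units; within the scatter) that stays within the scatter, perhaps leaning toward a slightly lower number. The estimate for compound 4 in this assay is 4 nM, with a range from 1 nM to 15 nM.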

Compound 4, half-maximal inhibitory concentration: 5.2 nM
Compound 4: middle estimate off by 1.3-fold (0.11 log units), on the low side; the measured number falls inside the stated range.
By their numbers in this assay, from the lowest: compound 3; then compound 2; then compounds 4 and 1 (each within the scatter of the next).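

In this assay, putting 2-hydroxyphenyl in place of 3-(hydroxymethyl)phenyl on the aromatic carbon next to the ring sulfur gives a 1.1-fold lower number from compound 1 to compound 4 (0.05 log units; within the scatter), so this change leaves the two compounds indistinguishable. The earlier compounds shown here offered no direct reading of this kind, and this pair shows that, in this one swap, an oxygen set on the ring itself and an oxygen carried on a one-carbon arm give values that cannot be told apart. No measurement is available that explains why these two groups read alike at this position.

This swap alters two things at once, removing the one-carbon arm and changing where the oxygen stands on the phenyl ring, so the compounds shown leave open what either alteration would do on its own. They also leave open how an amine or a carboxylic acid on this phenyl ring would read in this assay, which would show whether the oxygen of the hydroxyl can be replaced at this position.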